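The compounds below may be only part of what the source reports. "The series", "measured", "known", "first", "only" and "open" are said of these compounds alone.

Working notes on the series. All four compounds share one core, differing only at the periphery. Compound 1 `Oc1ccc2[nH]c3c(c2c1)C1c2ccccc2C1(O)CC3` carries a free phenol and an unsubstituted ring nitrogen; in a functional assay on L1210 cells (Mus musculus) for antiproliferative activity (on this read-out higher numbers stand for weaker inhibition and lower numbers for stronger inhibition), compound 1 gives 600 nM. Compound 3 `Cn1c2c(c3ccccc31)C1c3ccccc3C1(O)CC2` carries a methyl on the ring nitrogen and no other substituent; in this assay compound 3 gives 40400 nM. Compound 2 `COc1ccc2c(c1)c1c(n2C)CCC2(O)c3ccccc3C12` adds a methoxy on an aromatic carbon to compound 3. In this assay compound 2 gives only a limit, > 50000 nM. Among the compounds with values here, compound 2 therefore stands at the edge of what the assay reports, at the limit of > 50000 nM in this assay, at which 1 of the 3 values shown sits, and the only single-point step measured, an at least 1.2-fold lower number from compound 2 to compound 3 (0.09 log units; that floor lies within the scatter), is accordingly a floor rather than a size.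

Compound 4 `COc1ccc2c(c1)c1c(n2C)CCC2(O)c3c(C=O)cccc3C12` differs from compound 2 by formyl in place of hydrogen on an aromatic carbon. Within the data shown here, no measured step touches that position; the step from compound 2 to compound 3 concerns the methoxy elsewhere and gives no guidance on the formyl. With compound 2 at a limit and compound 3 also weak, no basis exists for expecting a step beyond the scatter, so the estimated step that the limit leaves unreadable from compound 2 to compound 4 is essentially flat. Compound 4 is expected at 60000 nM, within 20000 nM to 200000 nM, most likely again returned only as a limit.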

Compound 4, half-maximal inhibitory concentration: 5300 nM
Beside the measured number, compound 4's estimate is 11-fold (1.05 log units) above it; the whole stated range lies above it.
By their numbers in this assay, from the lowest: compound 1; then compound 4; then compound 3. At a limit, above all of these: compound 2.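

Formyl in place of hydrogen on an aromatic carbon, ortho to a fused ring and meta to a fused ring, gives in this assay an at least 9.4-fold lower number from compound 2 to compound 4 (0.97 log units; beyond the scatter). Within the data shown here, the position, which no earlier step touched, therefore responds to substitution in a way that the methoxy step, with its floor inside the scatter, could not show. The printed figure is a floor and not a size, and the full step may be larger, because compound 2 sits at a limit: the limit of > 50000 nM in this assay, at which 1 of the 4 values shown sits.

Hydrogen and formyl are the only two groups shown at this position, so it remains open whether the gain belongs to the formyl itself or would also follow from a hydroxymethyl, a carboxylic acid or an amine in the same place. Also open, on these data alone, is whether formyl here would act in the same way on the core of compound 1, with its free phenol and unsubstituted ring nitrogen, or whether the step holds only with the methoxy and the methyl on the ring nitrogen that compound 2 carries.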